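The source may hold more compounds than are shown below. What is called first, only, known or untested is meant among the compounds shown, and "the series" means these compounds.

Three analogues built on one shared core have been examined in an ADME assay on BJ cells (Homo sapiens) for antiproliferative activity, with a stated time of 72 h; on this read-out lower numbers stand for an effect already at smaller amounts and higher numbers for an effect only at larger amounts of compound. Compound 1 `COc1ccc(-c2cc(=O)c3c(OC)cc(OC)cc3[nH]2)cc1` gives in this assay > 62000 nM, which is a limit of this assay and not a number. Compound 2 `COc1ccc(-c2cc(=O)c3c(OC)cc(OC)cc3n2Cc2ccccc2)cc1` gives in this assay > 34400 nM, again a limit rather than a number. The step that the two limits leave unreadable from compound 1 to compound 2 therefore cannot be read in size or direction. Compound 3 `COc1ccc(-c2cc(=O)c3c(OC)cc(OC)cc3n2S(=O)(=O)c2ccc(C)c([N+](=O)[O-])c2)cc1` gives in this assay > 51700 nM, also a limit and not a number. Compound 3 thus stands at the limit of > 51700 nM in this assay, at which 1 of the 3 values shown sits. Among the compounds with values here, the two other values shown are the limit of > 34400 nM in this assay, at which 1 of the 3 values shown sits, and (the limit of > 62000 nM in this assay, at which 1 of the 3 values shown sits), so nothing measured so far is a number, and no step of readable size exists between any pair.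

The unmeasured compound 4 `COc1ccc(-c2cc(=O)c3c(OC)cc(OC)cc3n2S(=O)(=O)c2ccc(F)cc2)cc1` differs from compound 3 by 4-fluorophenyl in place of 4-methyl-3-nitrophenyl on a sulfonyl sulfur. Within the data shown here, every value shown is a limit; no measured step bears on this change, and no direction can be derived from the data. The expected step of an at least 1.0-fold lower number from compound 3 to compound 4 (0.01 log units; that floor lies within the scatter) is therefore estimated as nothing beyond the scatter. Compound 4 is expected, most likely again as a limit in this assay, at 50000 nM, with a range from 20000 nM to 120000 nM.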

Compound 4, half-maximal effective concentration: > 65500 nM
Compound 4 gave a limit, no number (the forecaster's own chance of this, stated with the estimate: 85%); at least 1.3-fold (0.11 log units) between middle value and limit.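

In this assay compound 4 gives > 65500 nM, a limit and not a number. With compound 1, compound 2 and compound 3 also standing at limits, none of the steps to compound 4 can be read in size or direction. The compounds shown leave open whether any group on the aromatic nitrogen changes the read-out, and at what concentration any of them reaches a half-maximal effect.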